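The source may report more compounds than this note shows. Statements on the series, on what has been measured and on what is new or still open speak of the compounds shown alone.

Compound 1 `Cc1cc(O)c(C(=O)/C=C/c2ccc(F)cc2)c(-c2ccccc2)c1C(=O)/C=C/c1ccc(F)cc1`: "not active" (no number reported)
Compound 2 `Cc1cc(O)c(C(=O)/C=C/c2ccc3ccccc3c2)c(-c2ccccc2)c1C(=O)/C=C/c1ccc2ccccc2c1`: "not active" (no number reported)
Compound 3 `COc1ccc(/C=C/C(=O)c2c(C)cc(O)c(C(=O)/C=C/c3ccc(OC)cc3)c2-c2ccc(OCc3ccccc3)cc2)cc1`: 28000 nM

In an ADME assay on HEK293 cells (Homo sapiens) for cytotoxicity, read by MTT assay, with a stated time of 24 h (on this read-out higher numbers stand for weaker inhibition and lower numbers for stronger inhibition), compound 2 gives "not active" (no number reported), so no single number stands for it, and compound 1 likewise gives "not active" (no number reported) in this assay. Going by the values given here, the one numbered value in this assay comes from compound 3, which gives 28000 nM. Compound 2 therefore stands among the entries without a number, and nothing in these three compounds shows an ordered pattern.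

Compound 4 `Cc1cc(O)c(C(=O)/C=C/c2ccc3ccccc3c2)c(-c2ccc(Cl)cc2)c1C(=O)/C=C/c1ccc2ccccc2c1` is not yet measured. It differs from compound 2 by chloro in place of hydrogen on an aromatic carbon. Among the compounds with values here, no pair of measured compounds that differ in one place is recorded, so there is no measured step to set the size of this change against. With compound 2 reported without a number and compound 3 at 28000 nM, the expectation is that compound 4 stays weak in this assay, with no step beyond the scatter in either direction. Compound 4 is estimated at 40000 nM, with a range from 15000 nM to 100000 nM.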

Compound 4, half-maximal inhibitory concentration: "not active" (no number reported)
Nothing numeric was reported for compound 4; the estimate stays without a comparison.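

Compound 4, like compound 2, is reported without a number in this assay, so no step can be read between them. No measurement shown here bears on the cause of this result. The compounds shown leave open what the chloro group does to this read-out.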